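Swapping the oxazole substituent for a methoxypyridine

The source may report more compounds than this note shows. Statements on the series, on what has been measured and on what is new or still open speak of the compounds shown alone.

Measured compounds:
compound 1 `CS(=O)(=O)c1cnc(C(=O)CCCCCCc2ccccc2)o1` — > 10000 nM
compound 2 `COc1cnc(C(=O)CCCCCCc2ccccc2)o1` — > 10000 nM
compound 3 `CNC(=O)c1cnc(C(=O)CCCCCCc2ccccc2)o1` — > 10000 nM

In an assay on HEK-293T cells for inhibition of diacylglycerol lipase-alpha (Homo sapiens), read by colorimetric assay (on this read-out higher numbers stand for weaker inhibition and lower numbers for stronger inhibition), compound 3 gives only a limit, > 10000 nM. Compound 1 likewise gives only a limit in this assay, > 10000 nM. Compound 2 also gives only a limit in this assay, > 10000 nM. All three sit at the limit of > 10000 nM in this assay, at which 3 of the 3 values shown sit, so the steps a step that the two limits leave unreadable from compound 1 to compound 2, a step that the two limits leave unreadable from compound 1 to compound 3 and a step that the two limits leave unreadable from compound 2 to compound 3 cannot be sized.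

Compound 4 `COc1ccc(-c2cnc(C(=O)CCCCCCc3ccccc3)o2)nc1` differs from compound 3 by 5-methoxypyridin-2-yl in place of methylcarbamoyl on an aromatic carbon. Among the measured compounds shown here, no measured step involves a group of this kind, and none is readable in size, so no direction can be taken from the data. The step of an at least 3.3-fold lower number from compound 3 to compound 4 (0.52 log units; beyond the scatter) is therefore an estimate with wide bounds, and compound 4 is expected near 3000 nM, between 300 nM and 30000 nM.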

Compound 4, half-maximal inhibitory concentration: > 10000 nM
Compound 4 ended at the assay's limit; the forecaster's own chance of this, stated with the estimate: 40%; at least 3.3-fold (0.52 log units) between middle value and limit.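

Compound 4 joins compound 1, compound 2 and compound 3 at the same limit, so no step among them can be read: the limit of > 10000 nM in this assay, at which 4 of the 4 values shown sit.

From the compounds shown here alone, how the methylsulfonyl, methoxy, methylcarbamoyl and 5-methoxypyridin-2-yl groups rank in this assay stays open.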